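Ester to Amide on a Scaffold Near the Assay Ceiling

The compounds below may be only part of what the source reports. "The series", "measured", "known", "first", "only" and "open" are said of these compounds alone.

In an assay for activation of interferon regulatory factor 3 (Homo sapiens), read by a luciferase reporter, with a stated time of 20 h (on this read-out lower numbers stand for an effect already at smaller amounts and higher numbers for an effect only at larger amounts of compound), compound 1 `CCn1nc(C)cc1C(=O)Nc1nc2cc(C(=O)OC)cc(OC)c2n1CCCNC(=O)OCc1ccccc1` gives 27600 nM. Compound 2 `CCn1nc(C)cc1C(=O)Nc1nc2cc(C(=O)OC)cnc2n1CCCNC(=O)OC(C)(C)C` returns only a limit, > 100000 nM, so its true potency is not a number. Compound 2 stands at the limit of > 100000 nM in this assay, at which 1 of the 2 values shown sits. Compound 3 `CCn1nc(C)cc1C(=O)Nc1nc2cc(C(N)=O)cnc2n1CCCNC(=O)OC(C)(C)C` differs from it by amino in place of methoxy on a carbonyl carbon. Within the data shown here, no measured pair shows this change, so no direction beyond the usual scatter can be foreseen. Compound 3 is expected near the ceiling, estimated at 100000 nM within 30000 nM to 300000 nM. This means an expected a number no higher from compound 2 to compound 3 (the limit leaves the size open).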

Compound 3, half-maximal effective concentration: > 100000 nM
Compound 3: no number, only a limit; the forecaster's own chance of this, stated with the estimate: 75%; the middle value lies on the limit itself.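

Compound 2 and compound 3 both return only a limit, not a number, and no step can be read between them. From the compounds shown here alone, whether carbamoyl in place of methoxycarbonyl changes the effect on the shared core stays open.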